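Swapping methylsulfonyl for sulfamoyl on a shared core

The compounds below may be only part of what the source reports. "The series", "measured", "known", "first", "only" and "open" are said of these compounds alone.

Of the compounds shown here, two have been tested in a functional assay on MCF7 cells (Homo sapiens) for antiproliferative activity, read by MTT assay, with a stated time of 48 h; on this read-out higher numbers stand for weaker inhibition and lower numbers for stronger inhibition. Compound 1, with the structure `Cc1cnc(Nc2ccc(S(N)(=O)=O)cc2)nc1Nc1nc2ccccc2s1`, reaches only a limit: in this assay compound 1 gives > 50000 nM, which is the edge of the assay rather than a number. Among the compounds with values here, compound 2, with the structure `CS(=O)(=O)c1ccc(Nc2nccc(Nc3nc4ccccc4s3)n2)cc1`, gives 10600 nM in this assay, and this is the only real number on hand. Compound 3, with the structure `NS(=O)(=O)c1ccc(Nc2nccc(Nc3nc4ccccc4s3)n2)cc1`, has not yet been measured; it differs from compound 2 by amino in place of methyl on a sulfonyl sulfur, or methylsulfonyl to sulfamoyl when the change is cut one bond further out. Within the data shown here, no measured pair shows this exact change on this core, so the expected step from compound 2 to compound 3 is small, not clearly beyond the usual scatter, and if anything toward weaker inhibition by a 1.4-fold higher number from compound 2 to compound 3 (0.15 log units; within the scatter). Compound 3 is therefore expected to give about 15000 nM in this assay, with a plausible range from 5000 nM to 50000 nM.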

Compound 3, half-maximal inhibitory concentration: 15300 nM
Compound 3: the middle estimate sits 1.0-fold (0.01 log units) below what was measured; measured number inside the range.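

In this assay, amino in place of methyl on a sulfonyl sulfur gives a 1.4-fold higher number from compound 2 to compound 3 (0.16 log units; within the scatter), so on this core the exchange of methylsulfonyl for sulfamoyl does not separate the two compounds. The other single change, hydrogen in place of methyl on an aromatic carbon, gives an at least 3.2-fold lower number from compound 1 to compound 3 (0.51 log units; beyond the scatter), which shows stronger inhibition with that hydrogen when sulfamoyl is kept. The value of compound 1 is a limit and not a number, so this step gives only a smallest size: the limit of > 50000 nM in this assay, at which 1 of the 3 values shown sits.

The compounds shown leave open whether a dimethylamino group or an ethyl chain on the sulfonyl sulfur would also stay within the scatter of compound 2. They also leave open what an ethyl group or a chlorine would do in place of that hydrogen on the aromatic carbon.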